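Swapping the sulfonamide heteroaryl on a thiourea scaffold

The source may hold more compounds than are shown below. What is called first, only, known or untested is meant among the compounds shown, and "the series" means these compounds.

Compound 1 `O=C(Nc1ccccc1)Nc1ccc(S(=O)(=O)Nc2ccnc3cc(C(F)(F)F)ccc23)cc1` gives 41000 nM in a functional assay on HeLa cells (Homo sapiens) for antiproliferative activity, read by sulforhodamine B assay, with a stated time of 48 h; on this read-out higher numbers stand for weaker inhibition and lower numbers for stronger inhibition.
Compound 2 `O=S(=O)(Nc1nccs1)c1ccc(N/C(S)=N\c2ccnc3cc(C(F)(F)F)ccc23)cc1` gives 95200 nM in this assay.

Of these two numbers, compound 2 holds the higher one, and the gap to compound 1 lies beyond the usual scatter. Compound 3 `COc1cc(NS(=O)(=O)c2ccc(N/C(S)=N\c3ccnc4cc(C(F)(F)F)ccc34)cc2)nc(OC)n1` differs from compound 2 only in the change (2,6-dimethoxypyrimidin-4-yl in place of 1,3-thiazol-2-yl on a sulfonamide nitrogen). Going by the values given here, no measured pair shows this step, so its size is unknown; both known values sit in the same weak range, and no shift beyond the scatter is expected. Compound 3 is therefore expected to give about 70000 nM in this assay, within 25000 nM to 200000 nM, a step of a 1.4-fold lower number from compound 2 to compound 3 (0.13 log units; within the scatter).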

Compound 3, half-maximal inhibitory concentration: 53800 nM
Estimate against measurement, compound 3: 1.3-fold (0.11 log units) above; the measured number falls inside the stated range.
By their numbers in this assay, from the lowest: compounds 1, 3 and 2 (each within the scatter of the next, the first and the last beyond it).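

In this assay, 2,6-dimethoxypyrimidin-4-yl in place of 1,3-thiazol-2-yl on a sulfonamide nitrogen gives a 1.8-fold lower number from compound 2 to compound 3 (0.25 log units; within the scatter). At this position, a five-membered and a six-membered aromatic ring, the latter with two methoxy groups, thus give numbers within the scatter of each other, and this single step reveals no sensitivity to the change. No evidence bears on this result. As far as these compounds go, whether an unsubstituted phenyl ring, a pyridine or a small methyl group on this sulfonamide nitrogen would shift the number beyond the scatter remains open.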